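A few compounds are considered here, and "the series" means these few. Any claim that something is new, unique, unknown or untested is made for them only; others in the source may bear on it.

In a functional assay on HeLa cells (Homo sapiens) for antiproliferative activity, read by MTT assay, with a stated time of 48 h (on this read-out higher numbers stand for weaker inhibition and lower numbers for stronger inhibition), compound 1 `Clc1ccccc1CSc1nnc(-c2cnccn2)o1` gives 23000 nM and compound 2 `Clc1ccccc1CSc1nnc(-c2cnccn2)s1` gives 28900 nM while compound 3 `Fc1cccc(F)c1CSc1nnc(-c2cnccn2)s1` gives 29200 nM on the same read-out. Compound 2 therefore stands among three numbers that all lie within the scatter of one another. Compound 4 `c1ccc(CSc2nnc(-c3cnccn3)s2)cc1` has not yet been measured. It departs from compound 2 by a single change hydrogen in place of chloro on an aromatic carbon that puts hydrogen in place of chloro on an aromatic carbon, ortho to a large group. Among the measured compounds shown here, no step between measured compounds shows this change alone, so the data offer no direct precedent. Compound 2 at 28900 nM and compound 3 at 29200 nM carry different substituents on that ring yet show no gap beyond the scatter, so in this assay no step beyond the scatter is expected, with only a slight lean towards a higher number. The expected step runs a 1.2-fold higher number from compound 2 to compound 4 (0.08 log units; within the scatter) and stays small. For compound 4 the estimate is 35000 nM with an expected range of 16000 nM to 75000 nM in this measurement.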

Compound 4, half-maximal inhibitory concentration: 34400 nM
Beside the measured number, compound 4's estimate is 1.0-fold (0.01 log units) above it, and the stated range covers the measured number.
By their numbers in this assay, from the lowest: compounds 1, 2, 3 and 4 (each within the scatter of the next).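

In this assay, the step of a 1.2-fold higher number from compound 2 to compound 4 (0.08 log units; within the scatter) isolates hydrogen in place of chloro on an aromatic carbon, ortho to a large group, which no earlier step had shown on its own. At this position, losing the chloro leaves a number that this read-out cannot tell apart from that of compound 2, so the chlorine atom is not needed to hold the antiproliferative reading at this level. Nothing measured here speaks to why this step is so small.

The compounds shown carry only hydrogen, chloro or fluoro on this ring, so it remains open whether any group at this position can move the number beyond the scatter. A methoxy group, an amine, a carboxylic acid or a longer chain on this aromatic carbon would test that.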